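A few compounds are considered here, and "the series" means these few. Any claim that something is new, unique, unknown or untested is made for them only; others in the source may bear on it.

The account starts from compound 2 `CC1(CO)OC[C@@H](n2ccc(N)nc2=O)O1` and moves to compound 3 `CC1(CO)OC[C@@H](n2cc(F)c(N)nc2=O)O1`, which is still unmeasured in a functional assay on L1210 cells (Mus musculus) for inhibition; a lower number here means a stronger inhibitor, a higher number a weaker inhibitor. For compound 2 the read-out in this assay is a limit of the assay, > 100000 nM, and not a number. Compound 1 `C[C@]1(CO)OC[C@@H](n2cc(F)c(N)nc2=O)O1` was also tested there. For compound 1 the result in this assay is again only a limit, > 100000 nM. Both results thus sit at the same point: the limit of > 100000 nM in this assay, at which 2 of the 2 values shown sit. Compound 2 therefore stands at the limit alongside compound 1, and no number from which an order could be read is available.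

The change that turns compound 2 into compound 3 is fluoro in place of hydrogen on an aromatic carbon. Going by the values given here, no measured step between two compounds is given here, so the size of this change has to be judged from the two limits alone. Because both results sit at the limit of > 100000 nM in this assay, at which 2 of the 2 values shown sit, a step from compound 2 to compound 3 of a step that the limit leaves unreadable from compound 2 to compound 3 is expected, that is, none beyond the scatter. For compound 3 the expected value in this assay is 150000 nM, within a range from 50000 nM to 500000 nM, most probably reported again only as a limit.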

Compound 3, half-maximal inhibitory concentration: > 100000 nM
Compound 3: a limit, no number (the forecaster's own chance of this, stated with the estimate: 85%); the middle value is on the limit's open side.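

In this assay compound 3 gives > 100000 nM, a limit of the assay and not a number. Going by these compounds alone, no step from compound 2 to compound 3, or from compound 1 to compound 3, can be read: the limit of > 100000 nM in this assay, at which 3 of the 3 values shown sit. The compounds shown leave open whether fluoro in place of hydrogen on an aromatic carbon, or the drawn configuration, alters inhibition at all.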